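The source may report more compounds than this note shows. Statements on the series, on what has been measured and on what is new or still open speak of the compounds shown alone.

In a functional assay on A549 cells (Homo sapiens) for inhibition, read by CCK-8 assay, with a stated time of 48 h (on this read-out lower numbers stand for stronger inhibition and higher numbers for weaker inhibition), compound 1 `COc1cc(-c2ccnc3cc(-c4ccc(Cl)cc4)nn23)cc(OC)c1OC` gives 3070 nM and compound 2 `Cn1ccc2cc(-c3cc4nccc(-c5ccc(F)cc5)n4n3)ccc21` gives 3520 nM. For the measured compounds named here, these two values lie within the scatter of each other, so compound 1 stands level with the only other compound measured so far. Compound 3 `COc1cc(-c2ccnc3cc(-c4ccccc4)nn23)cc(OC)c1OC` has yet to be measured in this assay. It differs from compound 1 by a single change, hydrogen in place of chloro on an aromatic carbon, so that 4-chlorophenyl becomes phenyl. Going by the values given here, no two measured compounds differ in one place only, so the data offer no measured step to go by. A small shift towards weaker inhibition is expected, one that may not pass beyond the scatter, and the estimated step is a 1.6-fold higher number from compound 1 to compound 3 (0.21 log units; within the scatter). Compound 3 is expected at 5000 nM, with an estimated range from 1800 nM to 14000 nM.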

Compound 3, half-maximal inhibitory concentration: 208 nM
The estimate for compound 3 lay 24-fold (1.38 log units) above the measured number; the measured number lies below the stated range.
By their numbers in this assay, from the lowest: compound 3; then compounds 1 and 2 (each within the scatter of the next).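

In this assay, the chloro of the 4-chlorophenyl group turns out to matter far more than a single atom might suggest: replacing it with hydrogen gives a 15-fold lower number from compound 1 to compound 3 (1.17 log units; beyond the scatter), a large step beyond the scatter. For the compounds shown here, the earlier compounds offered no comparison of this kind, so this is the first sign that this aromatic carbon, para to a large group, bears strongly on inhibition, and that on the core of compound 1 plain phenyl does better than 4-chlorophenyl. Nothing available accounts for the size of this step. Going by these compounds, whether an amine, a carboxylic acid or a nitrile at this position would keep the stronger inhibition of compound 3 remains open. So does whether the same change would have a similar effect on a different core.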